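Phenyl to 1-Methylimidazolyl on a Thiadiazole Core

The source may report more compounds than this note shows. Statements on the series, on what has been measured and on what is new or still open speak of the compounds shown alone.

The shared core is seen in compound 1 `CC(C)Oc1ccc(-c2nnc(-c3ccccc3)s2)cc1Cl`. Among the measured compounds shown here, in a physicochemical assay for lipophilicity, at pH 7.4 (a higher number here means a more lipophilic compound, a lower number a more polar compound), compound 1 gives 8.65, the highest of the two numbers so far; the nearest is compound 2 `CC(C)Oc1ccc(-c2nnc(-c3cnn(CC(=O)O)c3)s2)cc1Cl`, which in this assay gives 2.82, a gap that lies beyond the scatter. Compound 3 `CC(C)Oc1ccc(-c2nnc(-c3cncn3C)s2)cc1Cl` has not yet been measured. It differs from compound 1 in one place: 1-methyl-1H-imidazol-5-yl in place of phenyl on an aromatic carbon. For the measured compounds named here, no measured pair traces this exact change, so the size of the step rests on expectation alone. Compound 3 is expected to fall well below compound 1 in this assay, a step estimated as a number 2.45 log units lower from compound 1 to compound 3 (beyond the scatter), clearly beyond the scatter but short of the distance to compound 2. On that basis compound 3 is estimated at 6.2, within a range from 5 to 7.4.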

Compound 3, distribution coefficient: 5.7
Compound 3: the middle estimate sits 0.50 log units above what was measured; low and high end bracket the measured number.
By their numbers in this assay, from the lowest: compound 2; then compound 3; then compound 1.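

At this aromatic carbon of the shared core, 1-methyl-1H-imidazol-5-yl in place of phenyl gives a number 2.95 log units lower from compound 1 to compound 3 (beyond the scatter) in this assay, so this position responds strongly to the exchange even though both groups have 6 heavy atoms and neither carries a net charge. In this assay compound 3 gives 5.7, which places it between the printed values of compound 1 and compound 2 and shows that a group with no net charge at this position can cover a large part of the range seen so far. Nothing measured here accounts for the size of the step.

On these data alone, whether the step belongs to the imidazole ring as a whole or depends on its methyl group remains open. Also open, as far as these compounds go, is where a pyridyl ring or a phenyl ring bearing an amine would fall at this position.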